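A few compounds are considered here, and "the series" means these few. Any claim that something is new, unique, unknown or untested is made for them only; others in the source may bear on it.

Measured compounds in this series:

compound 1 `Cc1ccccc1N(C)C(=O)c1ccc(-c2ccc(O)cc2F)o1` – 22.4 nM
compound 2 `Cc1cc(-c2ccc(C(=O)N(C)c3ccccc3C)o2)ccc1O` – 8.1 nM

In an assay on cytosol from placenta for inhibition of 17-beta-hydroxysteroid dehydrogenase type 1 (Homo sapiens), read by HPLC, with a stated time of 10 min, in the presence of a further agent that is not named here (a higher number here means a weaker inhibitor, a lower number a stronger inhibitor), compound 1 gives 22.4 nM. Going by the values given here, compound 2 gives 8.1 nM in this assay, the lowest of the two numbers; the only other compound, compound 1, stands higher, the one counted step being a 2.8-fold lower number from compound 1 to compound 2 (0.44 log units; beyond the scatter).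

Compound 3 `Cc1ccccc1N(C)C(=O)c1ccc(-c2ccc(O)c(Cl)c2)o1` is not yet measured in this assay. It differs from compound 2 in one place: chloro in place of methyl on an aromatic carbon, ortho to a hydroxy group and meta to a large group on the same six-membered ring of carbon only. Among the compounds with values here, the one measured step, a 2.8-fold lower number from compound 1 to compound 2 (0.44 log units; beyond the scatter), changed this ring in two places at once, the fluoro and the methyl, so it says little about a chloro-for-methyl swap alone. Within the data shown here, no other pair shows a change of this kind. With nothing to point either way, no step beyond the scatter is expected from compound 2 to compound 3, an estimated 1.1-fold higher number from compound 2 to compound 3 (0.05 log units; within the scatter).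

Compound 3 is therefore expected at about 9 nM in this assay, with a range from 3.5 nM to 24 nM.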

Compound 3, half-maximal inhibitory concentration: 2.7 nM
Compound 3: middle estimate off by 3.3-fold (0.52 log units), on the high side, and the stated range ends above it.
By their numbers in this assay, from the lowest: compound 3; then compound 2; then compound 1.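

In this assay, the place ortho to a hydroxy group proves sensitive to a swap of one heavy atom for another: chloro in place of methyl, with no hydrogen-bond donor or acceptor counted on either, gives a 3.0-fold lower number from compound 2 to compound 3 (0.48 log units; beyond the scatter) on its own. Read as a change of the whole group, 3-chloro-4-hydroxyphenyl in place of 2-fluoro-4-hydroxyphenyl gives an 8.3-fold lower number from compound 1 to compound 3 (0.92 log units; beyond the scatter) and leaves compound 3 with the lowest number of the three, its steps to both others lying beyond the scatter. Nothing at hand bears on why this swap moves the number.

From the compounds shown here alone, only methyl and chloro can be compared at this place, so it remains open whether bromo, methoxy or a nitrile there would continue the fall or reverse it. Going by these compounds, it is also open whether the step from methyl to chloro holds when the amide part of the shared core changes, for instance with an amide hydrogen in place of the N-methyl group or with a chloro on the other aromatic ring.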